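Carbonyl substituent swap from compound 3 to compound 4

A few compounds are considered here, and "the series" means these few. Any claim that something is new, unique, unknown or untested is made for them only; others in the source may bear on it.

In a functional assay on PC-3 cells (Homo sapiens), read by MTT assay, with a stated time of 48 h (a higher number here means a weaker inhibitor, a lower number a stronger inhibitor), compound 3 `CCn1c(C(=O)N(CCC#N)CCC#N)ccc1C(CC)(CC)c1ccc(OCC(O)C(C)(C)C)c(C)c1` gives 7800 nM, the middle of three values. Compound 2 `CCn1c(C(=O)NCCCN(C)C)ccc1C(CC)(CC)c1ccc(OCC(O)C(C)(C)C)c(C)c1` gives 3100 nM, and compound 1 `CCOC(=O)CN(C)C(=O)c1ccc(C(CC)(CC)c2ccc(OCC(O)C(C)(C)C)c(C)c2)n1CC` gives 25500 nM.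

Compound 4 `CCn1c(C(=O)Oc2ccc(CCO)cc2)ccc1C(CC)(CC)c1ccc(OCC(O)C(C)(C)C)c(C)c1` differs from compound 3 on a carbonyl carbon: a group of 10 heavy atoms (8 carbon, 2 oxygen; one six-membered aromatic ring of carbon only) in place of a group of 9 heavy atoms (6 carbon, 3 nitrogen; no ring), on a carbonyl carbon.

All three measured steps are swaps at this carbonyl carbon: an 8.2-fold lower number from compound 1 to compound 2 (0.92 log units; beyond the scatter), a 3.3-fold lower number from compound 1 to compound 3 (0.51 log units; beyond the scatter) and a 2.5-fold higher number from compound 2 to compound 3 (0.40 log units; beyond the scatter). All are modest, they run in both directions, and none brings in an aromatic ring. A step of similar or smaller size is therefore expected, with no direction favoured.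

The estimate means a 1.2-fold higher number from compound 3 to compound 4 (0.06 log units; within the scatter), an expected step. For compound 4 the estimated value is 9000 nM, with an expected range of 3000 nM to 27000 nM.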

Compound 4, half-maximal inhibitory concentration: 6300 nM
For compound 4 the middle estimate is 1.4-fold (0.15 log units) above the measured one; low and high end bracket the measured number.
By their numbers in this assay, from the lowest: compound 2; then compounds 4 and 3 (each within the scatter of the next); then compound 1.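

In this assay, a group with a six-membered aromatic ring and no nitrogen fits on this carbonyl carbon without leaving the range of the earlier groups: a 1.2-fold lower number from compound 3 to compound 4 (0.09 log units; within the scatter), so this swap does not separate the two groups. The same group gives a 2.0-fold higher number from compound 2 to compound 4 (0.31 log units; beyond the scatter) and a 4.0-fold lower number from compound 1 to compound 4 (0.61 log units; beyond the scatter), which places it inside the modest spread already seen at this position. Nothing available bears on why these groups differ.

Going by these compounds, whether a carboxylic acid or a primary amine on this carbonyl carbon would move the number outside that spread remains open.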